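A few compounds are considered here, and "the series" means these few. Any claim that something is new, unique, unknown or untested is made for them only; others in the source may bear on it.

Among the measured compounds shown here, compound 2 `CCCCCn1c(-c2ccccc2)nc2c(NCc3ccccc3)ccnc21` is one of only two compounds so far tested in an assay on isolated protein for inhibition of high affinity 3',5'-cyclic-AMP phosphodiesterase 7A (Homo sapiens), read by cAMP accumulation, with a stated time of 20 min; on this read-out lower numbers stand for stronger inhibition and higher numbers for weaker inhibition. In this assay compound 2 gives only a limit of the assay, > 200000 nM. Compound 1 `CCCCCn1c(-c2ccco2)nc2c(N)ccnc21` likewise gives only a limit in this assay, > 200000 nM. Both values sit at the same limit (the limit of > 200000 nM in this assay, at which 2 of the 2 values shown sit), so compound 2 cannot be ranked against compound 1. Compound 3 `CCCCCn1c(-c2ccco2)nc2c(NCc3ccccc3)ccnc21` has not yet been measured. It differs from compound 2 by furan-2-yl in place of phenyl on an aromatic carbon. For the measured compounds named here, no measured pair shows this change. The step from compound 2 to compound 3 is expected to be a number no higher from compound 2 to compound 3 (the limit leaves the size open), within the usual scatter. Compound 3 is expected to give about 200000 nM, between 60000 nM and 700000 nM, most likely again only a limit.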

Compound 3, half-maximal inhibitory concentration: > 200000 nM
Compound 3 ended at the assay's limit (the forecaster's own chance of this, stated with the estimate: 85%); the middle value lies on the limit itself.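

No step can be read from compound 3 to compound 1 or compound 2, and all three compounds give only a limit: the limit of > 200000 nM in this assay, at which 3 of the 3 values shown sit. The compounds shown leave open whether furan-2-yl in place of phenyl, or benzyl in place of hydrogen, changes inhibition at all.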